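Hydroxyl Repeated on a Chain-Linked Core at the Limit

A few compounds are considered here, and "the series" means these few. Any claim that something is new, unique, unknown or untested is made for them only; others in the source may bear on it.

compound 1: `CCCCCc1cccc(NC(=O)NCCCCl)c1`, 26000 nM
compound 2: `CCCCC(O)c1cccc(NC(=O)NCCCCl)c1`, a limit, > 100000 nM
compound 3: `CCCCCc1cccc(NC(=O)CCCCl)c1`, a limit, > 100000 nM

In a functional assay on MCF7 cells (Homo sapiens) for antiproliferative activity, with a stated time of 48 h (on this read-out higher numbers stand for weaker inhibition and lower numbers for stronger inhibition), compound 1 gives 26000 nM. For compound 2 the assay reports only a limit, > 100000 nM. For compound 3 it likewise reports only a limit, > 100000 nM. The change from compound 1 to compound 2 is hydroxy in place of hydrogen on a saturated chain carbon bound to an aromatic carbon and a saturated chain carbon and made an at least 3.8-fold higher number from compound 1 to compound 2 (0.58 log units; beyond the scatter). The two cores differ by 3-chloropropyl in place of (3-chloropropyl)amino on a carbonyl carbon, a step of an at least 3.8-fold higher number from compound 1 to compound 3 (0.58 log units; beyond the scatter). Compound 4, `CCCCC(O)c1cccc(NC(=O)CCCCl)c1`, is not yet measured; it differs from compound 3 by hydroxy in place of hydrogen on a saturated chain carbon bound to an aromatic carbon and a saturated chain carbon, the same change as from compound 1 to compound 2, at the same place. Since compound 3 already sits at the limit of > 100000 nM in this assay, at which 2 of the 3 values shown sit, compound 4 is expected to stay there as well, with the step that the limit leaves unreadable from compound 3 to compound 4 expected to be unresolvable. Compound 4 is estimated at 200000 nM.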

Compound 4, half-maximal inhibitory concentration: > 100000 nM
Compound 4 ended at the assay's limit (the forecaster's own chance of this, stated with the estimate: 90%); the middle value lies beyond the limit too.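

Compound 4 gives only a limit (> 100000 nM), so the steps to it from compound 3 and from compound 2 cannot be read. As far as these compounds go, how far compound 2, compound 3 and compound 4 actually lie from one another stays open.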